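The source may report more compounds than this note shows. Statements on the series, on what has been measured and on what is new or still open speak of the compounds shown alone.

Within the data shown here, compound 1 `CC(C)(C)c1ccc(NC(=O)c2csc(Cc3c(Cl)cccc3Cl)n2)cc1` is the only compound here with a numerical result: in an assay on CHO cells, read by calcium flux (on this read-out higher numbers stand for weaker inhibition and lower numbers for stronger inhibition), compound 1 gives 570 nM. Compound 2 `O=C(Nc1ccccc1)c1csc(Cc2c(Cl)cccc2Cl)n1` carries hydrogen where compound 1 carries tert-butyl and sits at the limit of > 4000 nM in this assay, at which 1 of the 2 values shown sits. In this assay compound 2 gives > 4000 nM, which is a limit of the assay and not a measured number. The step of an at least 7.0-fold higher number from compound 1 to compound 2 (0.84 log units; beyond the scatter) shows that taking the tert-butyl away weakens inhibition clearly.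

Compound 3 `COc1ccc(NC(=O)c2csc(Cc3c(Cl)cccc3Cl)n2)cc1` differs from compound 1 in one place: methoxy in place of tert-butyl on an aromatic carbon. Methoxy brings fewer heavy atoms than tert-butyl, though more than the bare hydrogen of compound 2. Among the measured compounds shown here, the one measured step that bears on this change, the loss of the tert-butyl toward compound 2, therefore points to weaker inhibition, though probably not by the full amount of that step. For compound 3 the expected step is a 3.5-fold higher number from compound 1 to compound 3 (0.55 log units; beyond the scatter). Compound 3 is thus estimated at 2000 nM, within 800 nM to 5000 nM.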

Compound 3, half-maximal inhibitory concentration: > 4000 nM
Compound 3 gave a limit, no number; the forecaster's own chance of this, stated with the estimate: 30%; middle value at least 2.0-fold (0.30 log units) away from the limit.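

In this assay the change from tert-butyl to methoxy gives an at least 7.0-fold higher number from compound 1 to compound 3 (0.84 log units; beyond the scatter) and so matches the loss seen with bare hydrogen, as far as the limit allows it to be read. This shows that merely having a group at this place is not enough: methoxy, with 2 heavy atoms against the 4 of tert-butyl, does not keep the measurable inhibition of compound 1. The step between compound 2 and compound 3 cannot be read, because both compounds end at the same limit of the assay: the limit of > 4000 nM in this assay, at which 2 of the 3 values shown sit.

On these data alone, whether methoxy does any better than hydrogen therefore stays open. So does how much of the tert-butyl is needed, which a smaller branched group such as isopropyl, or a different one such as an amine, could help to show.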